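A Methyl in Place of Hydrogen on the Shared Core

The compounds below may be only part of what the source reports. "The series", "measured", "known", "first", "only" and "open" are said of these compounds alone.

Measured compounds:
compound 1 `CCCOc1cc(C(=O)Nc2nn[nH]n2)nc(-c2ccccc2)c1` gives 100%
compound 2 `O=C(Nc1nn[nH]n1)c1cccc(-c2ccccc2)n1` gives 74%

Both compounds were tested in a functional assay on the whole organism with Rattus norvegicus as the target, at a dose of 3 mg/kg by the oral route; a higher number here means a stronger effect of the compound at the dose given, a lower number a weaker effect. Going by the values given here, compound 2 stands lowest of the two numbers; its nearest neighbour is compound 1, and the single step between them, a number 26 percentage points lower from compound 1 to compound 2 (beyond the scatter), came with the change of hydrogen in place of propoxy on an aromatic carbon of the shared core.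

Compound 3 `Cc1cc(C(=O)Nc2nn[nH]n2)nc(-c2ccccc2)c1` has not yet been measured. It differs from compound 2 by methyl in place of hydrogen on an aromatic carbon

Among the compounds with values here, the only step that bears on this change is a number 26 percentage points lower from compound 1 to compound 2 (beyond the scatter), where a propoxy group at the same aromatic carbon stood with the higher number. The methyl group of compound 3 is a much smaller substituent than propoxy, so the step back upward is expected to be smaller than that one, though in the same direction. For compound 3 a modest rise is therefore expected, a number 11 percentage points higher from compound 2 to compound 3 (beyond the scatter).

The estimate for compound 3 in this assay is 85%, with a range from 65% to 100%.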

Compound 3, a percentage reported as inhibition, in the whole organism at one dose (the size of the read-out at that dose, not a potency): 50%
Compound 3: middle estimate off by 35 percentage points, on the high side; the measured number lies below the stated range.
By their numbers in this assay, from the lowest: compound 3; then compound 2; then compound 1.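

In this assay, the change at the aromatic carbon opposite the ring nitrogen did not follow the size of the entering group: a number 24 percentage points lower from compound 2 to compound 3 (beyond the scatter), so methyl went the opposite way from propoxy relative to hydrogen. Comparing the two substituted compounds directly gives the largest step of the three pairs, a number 50 percentage points lower from compound 1 to compound 3 (beyond the scatter), which shows that at this position the outcome depends on which group enters, and that filling the position with any group does not by itself raise the number. No measurement offered here accounts for why methyl and propoxy part in this way.

The compounds shown leave open whether the higher number of compound 1 goes with the ether oxygen on the aromatic carbon or with the length of the chain, a question that methoxy, ethoxy or a longer chain such as butoxy at the same carbon would address. They also leave open how a propyl group, which keeps the chain without the oxygen, or an amine at that carbon would stand against these three compounds.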